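Series notes: the step from compound 3 to compound 4

A few compounds are considered here, and "the series" means these few. Any claim that something is new, unique, unknown or untested is made for them only; others in the source may bear on it.

Compound 3 `C=CCc1cc(C(C)=O)c(O)cc1OCCCC#N` gives 6% in an assay on isolated protein for binding affinity to leukotriene B4 receptor 1 (Homo sapiens), tested at 1 uM (on this read-out lower numbers stand for less inhibition and higher numbers for more inhibition at the one concentration tested (going by the name of the read-out)), and stands at the low end of the three numbers measured. Compound 2 `CCCCc1cc(C(C)=O)c(O)cc1OCCCCC#N`, with 13% in this assay, lies within the scatter of compound 3, while compound 1 `CCCc1cc(C(C)=O)c(O)cc1OCCCCC#N`, with 37% in this assay, lies beyond it. Among the measured compounds shown here, the one step measured in a single place is a number 24 percentage points lower from compound 1 to compound 2 (beyond the scatter); it concerns the chain on the core and says nothing about the far end of the other chain.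

Compound 4 `C=CCc1cc(C(C)=O)c(O)cc1OCCCCCC(=O)NO` differs from compound 3 in 2-(hydroxycarbamoyl)ethyl in place of cyano on a saturated chain carbon, three bonds along the chain from an oxygen on an aromatic ring. For the measured compounds named here, no measured pair changes the cyano end of this chain, so the step from compound 3 to compound 4 rests on no precedent here, and compound 3 itself gives a low number in this assay. The step is therefore expected to be a number 14 percentage points higher from compound 3 to compound 4 (beyond the scatter), with wide uncertainty in both directions. Compound 4 is estimated at 20% in this assay, within a range of 0% to 55%.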

Compound 4, a percentage reported as inhibition, at one concentration (the size of the read-out at that concentration, not a potency): 28%
Estimate against measurement, compound 4: 8 percentage points below, and the stated range covers the measured number.
By their numbers in this assay, from the lowest: compounds 3 and 2 (each within the scatter of the next); then compounds 4 and 1 (each within the scatter of the next).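

In this assay the chain carbon three bonds along from an oxygen on an aromatic ring proves to be a place where the number moves, with a number 22 percentage points higher from compound 3 to compound 4 (beyond the scatter). Among the compounds shown here, the only earlier step in a single place concerned the chain on the core, so this is the first sign that the other chain also matters, and that 2-(hydroxycarbamoyl)ethyl can stand in place of cyano without a loss on this read-out. No independent measurement accompanies this change to account for the rise.

The change lengthens the chain and replaces the nitrile end in one step, so the share of each remains unresolved; a carboxylic acid or a primary amide on the same chain would separate them. As far as these compounds go, whether the step carries over to the propyl-bearing core of compound 1 also stays open.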